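The source may hold more compounds than are shown below. What is called first, only, known or untested is meant among the compounds shown, and "the series" means these compounds.

Compound 1 `O=C(Nc1ccc(OC(F)(F)F)cc1)NC1CCN(C(=O)C2CCCOC2)CC1` is the starting point. Among the measured compounds shown here, in a physicochemical assay for lipophilicity, read by HPLC, with a stated time of 90 min, tested at 100 uM (on this read-out lower numbers stand for lower lipophilicity and higher numbers for higher lipophilicity), compound 1 gives 3.42, the lowest of the two numbers measured so far. For the measured compounds named here, the only other measured compound, compound 2 `Cc1occc1C(=O)N1CCC(NC(=O)Nc2ccc(OC(F)(F)F)cc2)CC1`, gives 4.3 in this assay; the step between them is a number 0.88 log units higher from compound 1 to compound 2 (beyond the scatter), and it comes from a swap of the group on the carbonyl carbon, 2-methylfuran-3-yl in place of oxan-3-yl. Compound 3 `O=C(Nc1ccc(OC(F)(F)F)c(F)c1)NC1CCN(C(=O)C2CCCOC2)CC1` has not yet been measured. It differs from compound 1 by fluoro in place of hydrogen on an aromatic carbon. Going by the values given here, no measured step touches the aromatic ring, so the one measured step, which alters a different part of the molecule, offers little direct guidance beyond showing how far a single change can move this number. The change from compound 1 to compound 3 is a small one in what it adds and removes. A small step is therefore expected rather than a large one, most likely upward and possibly within the scatter. For compound 3 the expected step is a number 0.18 log units higher from compound 1 to compound 3 (within the scatter). Compound 3 is estimated at 3.6, within a range from 3.3 to 3.9.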

Compound 3, partition coefficient: 4.09
The estimate for compound 3 lay 0.49 log units below the measured number, outside the stated range (above it).
By their numbers in this assay, from the lowest: compound 1; then compounds 3 and 2 (each within the scatter of the next).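

On the six-membered aromatic ring, at the carbon ortho to a trifluoromethoxy group and meta to a large group, fluoro in place of hydrogen gives in this assay a number 0.67 log units higher from compound 1 to compound 3 (beyond the scatter), so this position is not a silent one for this read-out. Only one heavy atom enters, with no ring, no hydrogen-bond donors and no hydrogen-bond acceptors, yet the step is of the same modest class as the exchange of a whole group on the carbonyl carbon, a number 0.88 log units higher from compound 1 to compound 2 (beyond the scatter), and the values of compound 3 and compound 2 lie within the scatter of each other. Nothing in the data shown bears on the cause of the fluoro step.

On these data alone, it remains open whether a chloro, methyl or nitrile group on this same aromatic carbon would move the number as far as fluoro does, and whether fluoro on another carbon of the ring would do the same. As far as these compounds go, it is also open whether this fluoro step would keep its size with 2-methylfuran-3-yl in place of oxan-3-yl on the carbonyl carbon.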